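Swapping an Ethyl Ether for a Formate Ester

The compounds below may be only part of what the source reports. "The series", "measured", "known", "first", "only" and "open" are said of these compounds alone.

Compound 1 `O=C1C=CS(=O)(=O)c2ccccc21` gives 5.5% in a functional assay on the whole organism for inhibition, with Mus musculus as the target, at a dose of 10 mg/kg; a lower number here means less inhibition, a higher number more inhibition at the dose given (going by the name of the read-out).
Compound 2 `CCOCC1=CS(=O)(=O)c2ccccc2C1=O` gives 92.4% in this assay.

Within the data shown here, of the two compounds measured so far, compound 2 stands highest; the only other number belongs to compound 1, and the gap between them is well beyond the scatter. Among the measured compounds shown here, the single step known is a number 86.9 percentage points higher from compound 1 to compound 2 (beyond the scatter), where ethoxymethyl in place of hydrogen on a double-bonded ring carbon turned a low number into a much higher one.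

Compound 3 `O=COCC1=CS(=O)(=O)c2ccccc2C1=O` keeps that substituent but alters its outer end: formyl in place of ethyl on an oxygen on a saturated carbon. The ethoxymethyl group becomes (formyloxy)methyl, so the attachment to the core is unchanged and only the far end of the side chain differs.

For the measured compounds named here, the step from compound 1 to compound 2 shows that a group at this position matters greatly, but no measured pair tells how the outer ethyl versus formyl end affects the read-out. The expectation is therefore that compound 3 keeps a high number, with a modest drop expected, a number 20.4 percentage points lower from compound 2 to compound 3 (beyond the scatter), giving an estimated 72% in this assay, likely between 30% and 95%.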

Compound 3, a percentage reported as inhibition, in the whole organism at one dose (the size of the read-out at that dose, not a potency): 91.6%
Beside the measured number, compound 3's estimate is 19.6 percentage points below it, and the stated range covers the measured number.
By their numbers in this assay, from the lowest: compound 1; then compounds 3 and 2 (each within the scatter of the next).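

In this assay, the outer end of the side chain can go from ethyl to formyl with a number 0.8 percentage points lower from compound 2 to compound 3 (within the scatter), so this read-out at this dose does not tell the two ends apart. Placing (formyloxy)methyl in place of hydrogen on the double-bonded ring carbon gives a number 86.1 percentage points higher from compound 1 to compound 3 (beyond the scatter), which shows that the large rise seen earlier is not tied to ethoxymethyl alone, since a second side chain on the shared core reaches the same level. No measurement at hand explains why these two side chains read alike.

From the compounds shown here alone, it stays open whether the oxygen in the side chain is needed at all, since a plain propyl chain, an aminomethyl group or a carboxylic acid at the same ring carbon would each test how much of this side chain can change. Going by these compounds, because the read-out is the size of the inhibition at one dose and not a potency, it also stays open whether compound 2 and compound 3 would still read alike at a lower dose.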